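Same atoms, joined differently: estimating compound 4

The source may report more compounds than this note shows. Statements on the series, on what has been measured and on what is new or still open speak of the compounds shown alone.

- compound 1 `N#Cc1ccc(N2CCC(C(=O)N3N=CC[C@H]3c3cc(F)cc(F)c3)CC2)nn1` with 4.8 measured
- compound 2 `O=C(C1CCOC1)N1N=CCC1c1ccccc1` with 3 measured
- compound 3 `CC(C)(C)C(=O)N1N=CCC1c1ccccn1` with 3.5 measured

Among the compounds with values here, all three numbers come from a physicochemical assay for lipophilicity, read by HPLC, measured as chromatographic lipophilicity, at pH 7.4 (on this read-out lower numbers stand for lower lipophilicity and higher numbers for higher lipophilicity), and they are the only measurements so far. Compound 1 stands highest of them at 4.8 while compound 3 at 3.5 and compound 2 at 3 both sit lower, each gap lying beyond the usual scatter of repeated measurements.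

Compound 4 `N#Cc1cc(N2CCC(C(=O)N3N=CC[C@H]3c3cc(F)cc(F)c3)CC2)ncn1` has not yet been measured. It keeps the core of compound 1 and differs only in the group on an amine nitrogen in a ring. The change is this: a group of 8 heavy atoms (5 carbon, 3 nitrogen; one six-membered aromatic ring with 2 hetero atoms) in place of a group of 8 heavy atoms (5 carbon, 3 nitrogen; one six-membered aromatic ring with 2 hetero atoms), on an amine nitrogen in a ring and the two compounds have the same atoms, joined differently.

Within the data shown here, no two measured compounds differ in just one place, so no measured step speaks directly to this swap. Compound 2 and compound 3 show how far the numbers spread, but not what this change does. In this assay a small upward step is expected, one that may stay within the scatter, and a small fall cannot be excluded. The estimated change is a number 0.20 log units higher from compound 1 to compound 4 (within the scatter) and it remains a rough expectation. For compound 4 the estimated value is 5 with an expected range from 4.6 to 5.4 until a measurement is available.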

Compound 4, distribution coefficient: 5
Beside the measured number, compound 4's estimate shows no gap at the digits printed; the measured number falls inside the stated range.
By their numbers in this assay, from the lowest: compound 2; then compound 3; then compounds 1 and 4 (each within the scatter of the next).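

Within the data shown here, this pair gives the first measured step here that changes a single place: on an amine nitrogen in a ring, one group of 8 heavy atoms gives way to another with the same atoms, joined differently. In this assay the step is a number 0.20 log units higher from compound 1 to compound 4 (within the scatter), so on this read-out the two arrangements cannot be told apart, and this one rearrangement at this position leaves no measurable mark beyond what repeated measurements would show. Nothing measured here explains the result or ties it to any feature of the two groups.

Both groups carry the nitrile, so the compounds shown cannot say what a different substituent on the aromatic ring would do at this position, such as a carboxylic acid or a primary amine in place of the nitrile. Among these compounds, they also leave open whether the same rearrangement would give a similar step on another core, since this is the only such pair and compound 2 and compound 3 differ from it in more than one place.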